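The source may hold more compounds than are shown below. What is called first, only, known or untested is meant among the compounds shown, and "the series" means these compounds.

Measured so far in a physicochemical assay for lipophilicity, using the shake flask method, measured as octanol-water partition, at pH 7.4; on this read-out lower numbers stand for lower lipophilicity and higher numbers for higher lipophilicity:
- Compound 1 (`CC(=O)N[C@@H]1CCC[C@H](C(=O)Nc2cc(-c3cnn4c3CCCC4)ccn2)C1`): 2.4
- Compound 2 (`CC(=O)N[C@@H]1CCC[C@H](C(=O)Nc2cc(-c3cnn4c3CCC4)c(Cl)cn2)C1`): 2.9
- Compound 3 (`CC(=O)N[C@@H]1CCC[C@H](C(=O)Nc2cc(-c3cnn4c3CC(C)(C)C4)c(F)cn2)C1`): 3.3

Of these three, compound 2 has the second highest number. It lies below compound 3 and above compound 1, and both gaps are beyond the usual scatter.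

The next compound to be measured is compound 4 (`CC(=O)N[C@@H]1CCC[C@H](C(=O)Nc2cc(-c3cnc4n3CC(C)(C)C4)c(Cl)cn2)C1`). Its difference from compound 2 is a group of 10 heavy atoms (8 carbon, 2 nitrogen; one five-membered non-aromatic ring with 1 hetero atom, one five-membered aromatic ring with 2 hetero atoms) in place of a group of 8 heavy atoms (6 carbon, 2 nitrogen; one five-membered non-aromatic ring with 1 hetero atom, one five-membered aromatic ring with 2 hetero atoms), on an aromatic carbon. That carbon sits on a six-membered aromatic ring, ortho to a chloro group and opposite the ring nitrogen.

Going by the values given here, no measured pair shows this change on its own, so the available numbers cannot give its size directly. Only a small downward movement in this assay is expected, with no step beyond the scatter. In numbers, the expected change is a number 0.20 log units lower from compound 2 to compound 4 (within the scatter).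

Compound 4 is therefore estimated at 2.7, with an expected range from 2.2 to 3.2.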

Compound 4, distribution coefficient: 3.6
Estimate against measurement, compound 4: 0.90 log units below; the measured number lies above the stated range.
By their numbers in this assay, from the lowest: compound 1; then compound 2; then compounds 3 and 4 (each within the scatter of the next).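

In this assay, the exchange on the aromatic carbon opposite the ring nitrogen comes with a number 0.70 log units higher from compound 2 to compound 4 (beyond the scatter) and shows that this position is sensitive to the structure of the group it carries. The group of 10 heavy atoms and the group of 8 heavy atoms have the same ring types and the same counts of hydrogen-bond donors and acceptors, so the step arises between groups that those counts do not tell apart. No measurement at hand explains the size or direction of this step.

Going by these compounds alone, no pair shows how much of the step belongs to the added carbon atoms and how much to the different placement of the ring nitrogens. As far as these compounds go, how an amine or a carboxylic acid on this same aromatic carbon would read in this assay also remains open.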